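This account rests on a few compounds, and the source may have more. Where it says the series, first, only, none or still open, it means among the compounds named here.

Of the compounds shown here, three of one series have been measured so far in a functional assay on A549 cells (Homo sapiens) for antiproliferative activity, read by sulforhodamine B assay, with a stated time of 48 h; a higher number here means a weaker inhibitor, a lower number a stronger inhibitor. Compound 1 `COc1cc(OC)c2sc(-c3ccc(N/C=C\C(=O)c4ccc(OC)c([N+](=O)[O-])c4)c(C)c3)nc2c1` gives 12100 nM in this assay. Compound 3 `COc1cc(OC)c2sc(-c3ccc(N/C=C\C(=O)c4ccc(OC)c(F)c4)c(C)c3)nc2c1` differs from compound 1 by a single change, (fluoro in place of nitro on an aromatic carbon), and in this assay compound 3 gives 15300 nM; the step is a 1.3-fold higher number from compound 1 to compound 3 (0.10 log units; within the scatter). Compound 2 `COc1ccc(C(=O)/C=C\Nc2ccc(-c3nc4cc(OC)c(OC)c(OC)c4s3)cc2)cc1[N+](=O)[O-]` carries a different core; the difference between the two cores is not broken down here. In this assay compound 2 gives 21200 nM, and the three numbers all sit within the usual scatter of one another, so no ordering among them can be read.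

Compound 4 `COc1ccc(C(=O)/C=C\Nc2ccc(-c3nc4cc(OC)c(OC)c(OC)c4s3)cc2)cc1F` has not yet been measured. Its relation to compound 2 is fluoro in place of nitro on an aromatic carbon, the same change that separates compound 3 from compound 1, at the same kind of place. Since that change gave only a 1.3-fold higher number from compound 1 to compound 3 (0.10 log units; within the scatter), the step from compound 2 to compound 4 is expected to be similarly small, a 1.2-fold higher number from compound 2 to compound 4 (0.09 log units; within the scatter), because compound 2 gives 21200 nM and the earlier step was within the scatter. On that basis compound 4 is estimated at 26000 nM in this assay, with a plausible range from 12000 nM to 55000 nM.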

Compound 4, half-maximal inhibitory concentration: 15500 nM
Estimate against measurement, compound 4: 1.7-fold (0.22 log units) above; low and high end bracket the measured number.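

In this assay, putting fluoro in place of nitro on the core of compound 2 gives a 1.4-fold lower number from compound 2 to compound 4 (0.14 log units; within the scatter). Set beside the same change on the core of compound 1, this step does not differ from the earlier one: the same change on two cores in this assay, a 1.3-fold higher number (0.10 log units; within the scatter) from compound 1 to compound 3 and a 1.4-fold lower number (0.14 log units; within the scatter) from compound 2 to compound 4, 1.7-fold (0.24 log units) apart, within the scatter of two such steps The two pairs therefore show that, on both cores, this change leaves the number within the scatter, so the 4-methoxy-3-nitrophenyl and 3-fluoro-4-methoxyphenyl groups cannot be told apart here, and the opposite signs of the two steps cannot be read as a dependence on the core; with only two pairs, however, this does not show that the change would behave the same way on any other core.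

The compounds shown leave open whether another group at the same place, such as an amine or a carboxylic acid, would move the number beyond the scatter on either core. They also leave open how the fluoro and nitro compounds would compare in any other cell line.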